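The source may hold more compounds than are shown below. What is called first, only, known or untested is meant among the compounds shown, and "the series" means these compounds.

Measured so far in a functional assay on Jurkat cells (Homo sapiens); a lower number here means a stronger inhibitor, a higher number a weaker inhibitor:

Compound 1 `C[C@H](NC(=O)C(=O)Nc1cccnc1N(C)C)C(=O)N[C@@H](CC(=O)O)C(=O)COc1c(F)c(F)cc(F)c1F` gives 27 nM
Compound 2 `Cc1ccccc1CNC(=O)C(=O)N[C@@H](C)C(=O)N[C@@H](CC(=O)O)C(=O)COc1c(F)c(F)cc(F)c1F` gives 52 nM

Compound 2 at 52 nM and compound 1 at 27 nM lie within the scatter of each other, so the two cannot be ranked. Compound 3 `Cc1cccc(CNC(=O)C(=O)N[C@@H](C)C(=O)N[C@@H](CC(=O)O)C(=O)COc2c(F)c(F)cc(F)c2F)c1` has not yet been measured. It has the same atoms as compound 2, joined differently, with 3-methylphenyl in place of 2-methylphenyl on a saturated chain carbon bound to an amide-type nitrogen and so carries 3-methylphenyl in place of 2-methylphenyl on a saturated chain carbon bound to an amide-type nitrogen. For the measured compounds named here, no measured step moves this methyl group, and only one step offers any guide. Exchanging a whole group at this end of the molecule gave a 1.9-fold higher number from compound 1 to compound 2 (0.28 log units; within the scatter) and stayed within the scatter. A step beyond the scatter is therefore not expected in this assay for the smaller change, and the data favour no direction. The expected step is a 1.2-fold higher number from compound 2 to compound 3 (0.06 log units; within the scatter) and this estimate stays within the scatter. Compound 3 is estimated at 60 nM with an expected range from 25 nM to 150 nM overall.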

Compound 3, half-maximal inhibitory concentration: 127 nM
Estimate against measurement, compound 3: 2.1-fold (0.33 log units) below; the measured number falls inside the stated range.
By their numbers in this assay, from the lowest: compounds 1 and 2 (each within the scatter of the next); then compound 3.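

In this assay, moving only the methyl group, with 3-methylphenyl in place of 2-methylphenyl on a saturated chain carbon bound to an amide-type nitrogen, gives a 2.4-fold higher number from compound 2 to compound 3 (0.39 log units; beyond the scatter) and shows that this end of the molecule responds to where the methyl group sits, even with the same atoms present. Against the earlier exchange of whole groups, which stayed within the scatter, the whole-group exchange at this same end gives a 4.7-fold higher number from compound 1 to compound 3 (0.67 log units; beyond the scatter) and so separates compound 3 from compound 1, while compound 1 and compound 2 remain unranked. No measurement at hand explains why the location of the methyl group matters.

The compounds shown leave open whether an unsubstituted benzyl group would read with compound 2 or with compound 3. They also leave open whether a methoxy group or a chlorine atom in place of the methyl group would show the same dependence on location.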